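The compounds below may be only part of what the source reports. "The series", "measured", "known", "first", "only" and "open" are said of these compounds alone.

In a functional assay on PC-3 cells (Homo sapiens) for cytotoxicity, read by MTT assay (a higher number here means a weaker inhibitor, a lower number a stronger inhibitor), compound 2 `Cc1ccc(Nc2nc(C)c(C(=O)/C=C/c3ccccc3Cl)s2)cc1` gives > 25000 nM, which is a limit of the assay rather than a measured number. Compound 1 `COc1cccc(/C=C/C(=O)c2sc(Nc3ccc(Cl)cc3)nc2C)c1` likewise gives only the limit > 25000 nM in this assay. Both results therefore rest at the limit of > 25000 nM in this assay, at which 2 of the 2 values shown sit. Compound 3 `COc1cccc(/C=C/C(=O)c2sc(Nc3ccc(C)cc3)nc2C)c1` differs from compound 2 in one place: 3-methoxyphenyl in place of 2-chlorophenyl on a double-bonded chain carbon bound to a double-bonded chain carbon. For the measured compounds named here, no pair of measured compounds differing in a single place is available here, so the change is expected to move potency no further than the scatter, a step that the limit leaves unreadable from compound 2 to compound 3. Compound 3 is expected to give 30000 nM, within a range from 12000 nM to 80000 nM, most probably reported once more only as a limit.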

Compound 3, half-maximal inhibitory concentration: > 25000 nM
Compound 3: only a limit was reported (the forecaster's own chance of this, stated with the estimate: 80%); the middle value lies beyond the limit too.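

No step can be read among compound 1, compound 2 and compound 3, since all three give only a limit: the limit of > 25000 nM in this assay, at which 3 of the 3 values shown sit. As far as these compounds go, how far any of these changes moves potency in this assay stays open.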